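Isobutyl for Isopropyl on the Ring Amide Nitrogen

The source may hold more compounds than are shown below. What is called first, only, known or untested is meant among the compounds shown, and "the series" means these compounds.

Of the compounds shown here, three sharing one core have been measured in an assay on HEK293 cells for positive allosteric modulation of metabotropic glutamate receptor 2 (Rattus norvegicus), read by thallium flux; on this read-out higher numbers stand for larger maximal responses and lower numbers for smaller maximal responses. Compound 1 `O=C(O)c1cc(-c2cccc(COc3ccc4c(c3)CN(c3ccccc3)C4=O)c2)ccc1Cl` gives 86.2%. Compound 2 `O=C(O)c1cc(-c2cccc(COc3ccc4c(c3)CN(Cc3ccc(C(F)(F)F)cc3)C4=O)c2)ccc1Cl`, which carries a 4-(trifluoromethyl)benzyl on the amide-type nitrogen in the ring, gives 86.7%. Compound 3 `CC(C)N1Cc2cc(OCc3cccc(-c4ccc(Cl)c(C(=O)O)c4)c3)ccc2C1=O`, with isopropyl on that nitrogen, gives 88.1%. Compound 3 stands with compounds 1 and 2 in a narrow band: the steps of a number 1.9 percentage points higher from compound 1 to compound 3 (within the scatter) and a number 1.4 percentage points higher from compound 2 to compound 3 (within the scatter) both lie within the scatter, as does a number 0.5 percentage points higher from compound 1 to compound 2 (within the scatter). The group on the amide-type nitrogen has thus been varied from phenyl through 4-(trifluoromethyl)benzyl to isopropyl without any movement in the maximal response that rises above the usual spread of repeated measurements.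

Compound 4 `CC(C)CN1Cc2cc(OCc3cccc(-c4ccc(Cl)c(C(=O)O)c4)c3)ccc2C1=O` is the next member: isobutyl in place of isopropyl on an amide-type nitrogen in a ring. Among the compounds with values here, the steps that bear on it are those that changed the same nitrogen substituent, the one arriving at compound 3 from compound 1 and the one from compound 2, and each was small. The expected step in this assay is therefore a number 0.1 percentage points lower from compound 3 to compound 4 (within the scatter), nothing beyond the scatter in either direction. Compound 4 is estimated at 88%, with a range from 78% to 97%.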

Compound 4, largest response reached (Emax), in percent of the reference or control that the assay uses: 63.9%
For compound 4 the middle estimate is 24.1 percentage points above the measured one, and the stated range ends above it.
By their numbers in this assay, from the lowest: compound 4; then compounds 1, 2 and 3 (each within the scatter of the next).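

Within the data shown here, until this result the group on the amide-type nitrogen in the ring had seemed free to vary, but in this assay isobutyl in place of isopropyl gives a number 24.2 percentage points lower from compound 3 to compound 4 (beyond the scatter) and so shows that the maximal response does depend on this position, even for a change between two such closely related groups. A saturated chain carbon bound to that nitrogen does not by itself go with the lower number, since compound 2 carries one too: isopropyl in place of 4-(trifluoromethyl)phenyl on that carbon gives a number 22.8 percentage points lower from compound 2 to compound 4 (beyond the scatter) and isobutyl in place of phenyl on the nitrogen gives a number 22.3 percentage points lower from compound 1 to compound 4 (beyond the scatter) as well, leaving compound 4 apart from the other three. Nothing available here accounts for this separation.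

As far as these compounds go, whether the lower response belongs to isobutyl alone or also appears with a straight propyl or butyl chain, or with cyclopropylmethyl, stays open. From the compounds shown here alone, it is equally open whether an ethyl or a methyl on that nitrogen would stay with compounds 1, 2 and 3 or fall with compound 4.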